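Swapping a methylphenyl for a methylpyrrole on a spiro-piperidine core

A few compounds are considered here, and "the series" means these few. Any claim that something is new, unique, unknown or untested is made for them only; others in the source may bear on it.

Compound 1 `Cc1ccc(CN2CCC3(CC2)OCCc2sccc23)cc1` carries a 4-methylphenyl on the saturated chain carbon bound to the ring amine nitrogen of the shared core. In an ADME assay on microsomes from liver (Mus musculus) for metabolic stability, read by LC-MS, using NADPH, with a stated time of 30 min, tested at 0.5 uM (on this read-out lower numbers stand for slow clearance and higher numbers for fast clearance), compound 1 gives > 30 mL/min/g, which is a limit of the assay rather than a number. For the measured compounds named here, its only measured neighbour, compound 2 `c1ccc(Oc2ccc(CN3CCC4(CC3)OCCc3sccc34)cc2)cc1`, carries a phenoxy in place of methyl on an aromatic carbon, and in this assay compound 2 gives 28.8 mL/min/g. Going by the values given here, the single measured step is an at least 1.0-fold lower number from compound 1 to compound 2 (0.01 log units; that floor lies within the scatter), so the two compounds stand together at the fast end of the scale, and compound 1 is known only by its limit.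

The unmeasured compound 3 `Cc1ccc(CN2CCC3(CC2)OCCc2sccc23)[nH]1` differs from compound 1 as follows: 5-methyl-1H-pyrrol-2-yl in place of 4-methylphenyl on a saturated chain carbon bound to an amine nitrogen in a ring. Among the compounds with values here, no measured step touches this kind of change; the one step known concerns a substituent on the aromatic ring, not the ring itself. Compound 3 is therefore expected near where compound 1 sits, with a step of an at least 1.0-fold lower number from compound 1 to compound 3 (0.02 log units; that floor lies within the scatter) and an estimate of 28 mL/min/g ranging from 12 mL/min/g to 60 mL/min/g, and because compound 1 sits at the limit of > 30 mL/min/g in this assay, at which 1 of the 2 values shown sits, the chance that compound 3 also returns only a limit is substantial.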

Compound 3, intrinsic clearance in a liver preparation (reported as CLH), per the amount of preparation that the assay uses: 28.7 mL/min/g
Compound 3: middle estimate off by 1.0-fold (0.01 log units), on the low side; the range from low to high includes it.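

Where compound 2 concerned only a substituent on the aromatic ring, compound 3 replaces the ring itself, with 5-methyl-1H-pyrrol-2-yl in place of 4-methylphenyl on a saturated chain carbon bound to an amine nitrogen in a ring, and in this assay this change gives an at least 1.0-fold lower number from compound 1 to compound 3 (0.01 log units; that floor lies within the scatter). Compound 3 returns a number rather than a limit, and it shows that a five-membered aromatic ring with 1 hetero atom and 1 hydrogen-bond donor still leaves the compound at the fast end of the scale. The true size of this step stays unknown because compound 1 is known only by a limit: the limit of > 30 mL/min/g in this assay, at which 1 of the 3 values shown sits.

The compounds shown leave open whether any group at this place can bring the number clearly down in this assay, for example a pyridine ring, a carboxylic acid on the aromatic ring or a longer chain. They also leave open whether the pyrrole without its methyl would read differently from compound 3, and how much of the fast clearance belongs to the shared core rather than to the group on it.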